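The source may hold more compounds than are shown below. What is called first, only, known or untested is meant among the compounds shown, and "the series" means these compounds.

Compound 2 `CCCC#Cc1c(C#N)ncn1C1O[C@H](CO)[C@@H](O)[C@H]1O` stands as the weaker of the two measured compounds in a functional assay on L1210 cells (Mus musculus) for inhibition; on this read-out lower numbers stand for stronger inhibition and higher numbers for weaker inhibition: compound 2 gives 14.8 ug/mL, whereas compound 1 `N#Cc1ncn(C2O[C@H](CO)[C@@H](O)[C@H]2O)c1C#CCCO` gives 3.3 ug/mL. Among the measured compounds shown here, the only measured step, a 4.5-fold higher number from compound 1 to compound 2 (0.65 log units; beyond the scatter), comes from a methyl in place of hydroxy on a saturated chain carbon, two bonds along the chain from a triple-bonded carbon. Compound 3 `N#Cc1ncn(C2O[C@H](CO)[C@@H](O)[C@H]2O)c1C#Cc1ccccc1` differs from compound 2 by phenyl in place of propyl on a triple-bonded carbon. For the measured compounds named here, no measured step bears directly on this change: the single known step concerns a hydroxy on a saturated chain, not the replacement of a propyl by an aromatic ring, so the direction of the move from compound 2 to compound 3 cannot be read from the two values in hand. A step of modest size in either direction, or none beyond the scatter, is what can be expected. The estimate for this assay is therefore a step of a 1.9-fold lower number from compound 2 to compound 3 (0.27 log units; within the scatter). On that basis compound 3 is expected to give about 8 ug/mL, with a range from 2 ug/mL to 40 ug/mL.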

Compound 3, half-maximal inhibitory concentration: 80.3 ug/mL
Compound 3: the middle estimate sits 10-fold (1.00 log units) below what was measured; measured number above the stated range.
By their numbers in this assay, from the lowest: compound 1; then compound 2; then compound 3.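

In this assay the group on the triple-bonded carbon proves sensitive to more than the hydroxy on the chain: phenyl in place of propyl gives a 5.4-fold higher number from compound 2 to compound 3 (0.73 log units; beyond the scatter) and so moves the number further from that of compound 1, not back toward it. Phenyl in place of 2-hydroxyethyl gives a 24-fold higher number from compound 1 to compound 3 (1.39 log units; beyond the scatter) as the only large step among the three compounds, and the order of their numbers shows that neither replacement of the hydroxy-bearing chain has matched compound 1 so far. Nothing measured here accounts for either step.

From the compounds shown here alone, whether a phenyl ring carrying a hydroxy or an amine would bring the number back toward that of compound 1 remains open, and so does the effect of a pyridine ring on the triple-bonded carbon. Among chains, it is also unknown how a longer chain bearing a hydroxy, a chain ending in a carboxylic acid, or a simple methyl in place of propyl would compare with the three compounds shown.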